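The compounds below may be only part of what the source reports. "The series", "measured", "known", "first", "only" and "open" are said of these compounds alone.

Measured compounds:
- compound 1 `O=C1/C(=C/c2ccccc2)NS(=O)(=O)c2ccccc21`: 660 nM
- compound 2 `O=C1/C(=C/c2cccc(Br)c2)NS(=O)(=O)c2ccccc21`: > 200000 nM
- compound 3 `O=C1/C(=C/c2cccc(F)c2)NS(=O)(=O)c2ccccc21`: 3190 nM

All three share one core and were tested in an assay for inhibition of alkaline phosphatase, tissue-nonspecific isozyme (Homo sapiens), read by spectrophotometry, with stated times of 10 min and 20 min; on this read-out lower numbers stand for stronger inhibition and higher numbers for weaker inhibition. In this assay compound 1 gives 660 nM, the lowest of the two numbers reported. Its nearest neighbour is compound 3, and the change is a 4.8-fold higher number from compound 1 to compound 3 (0.68 log units; beyond the scatter). For compound 2 the assay reports only a limit, (the limit of > 200000 nM in this assay, at which 1 of the 3 values shown sits), not a number. The step of an at least 300-fold higher number from compound 1 to compound 2 (2.48 log units; beyond the scatter) is therefore a large one.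

The next compound, compound 4 `O=C1/C(=C/c2ccc(F)cc2)NS(=O)(=O)c2ccccc21`, differs from compound 1 by fluoro in place of hydrogen on an aromatic carbon, on an aromatic carbon of a six-membered aromatic ring of carbon only, para to a large group. Within the data shown here, two measured steps bear on it: the fluoro step a 4.8-fold higher number from compound 1 to compound 3 (0.68 log units; beyond the scatter), which was modest, and the bromo step an at least 300-fold higher number from compound 1 to compound 2 (2.48 log units; beyond the scatter), which was large. A fluoro group is the smaller of the two, so a modest rise in the number is expected. Compound 4 is expected to give 1800 nM, most likely between 500 nM and 6000 nM. The expected step is a 2.7-fold higher number from compound 1 to compound 4 (0.44 log units; beyond the scatter).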

Compound 4, half-maximal inhibitory concentration: 1350 nM
Estimate against measurement, compound 4: 1.3-fold (0.12 log units) above; low and high end bracket the measured number.
By their numbers in this assay, from the lowest: compound 1; then compound 4; then compound 3. At a limit, above all of these: compound 2.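

Fluoro in place of hydrogen, para to a large group, gives only a modest change, with a 2.0-fold higher number from compound 1 to compound 4 (0.31 log units; beyond the scatter), so a second ring place now shows that a fluoro group is tolerated with a modest rise in the number. The place of the fluoro itself also matters, because the two fluorinated compounds are separated by a modest step, with a 2.4-fold lower number from compound 3 to compound 4 (0.37 log units; beyond the scatter), a difference that a single fluoro compound could not show. The large step of an at least 140-fold lower number from compound 2 to compound 4 (2.17 log units; beyond the scatter) rests on a limit for compound 2, not on a number: the limit of > 200000 nM in this assay, at which 1 of the 4 values shown sits.

From the compounds shown here alone, whether a bromo group para to a large group would behave like the fluoro group there stays open. So does how a methoxy group, an amine or a carboxylic acid at that place would compare.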